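Pyrimidinyl Thioether in Place of a Tetrazolyl Thioether

This account rests on a few compounds, and the source may have more. Where it says the series, first, only, none or still open, it means among the compounds named here.

Compound 2 `O=C(CSc1nnnn1-c1ccccc1)N/N=c1/scc(-c2ccccc2)n1-c1ccccc1` gives the highest of the two numbers measured in an ADME assay on NIH3T3 cells (Mus musculus) for cytotoxicity, read by MTT assay, with a stated time of 24 h (on this read-out higher numbers stand for weaker inhibition and lower numbers for stronger inhibition), namely 417 ug/mL. Compound 3 `O=C(CSc1nnnn1-c1ccccc1)N/N=c1/scc(-c2ccc(Cl)cc2)n1-c1ccccc1`, which carries chloro in place of hydrogen on an aromatic carbon, gives 313 ug/mL in this assay. The step of a 1.3-fold lower number from compound 2 to compound 3 (0.12 log units; within the scatter) lies within the scatter. Compound 1 `O=C(CSc1ncccn1)N/N=c1/scc(-c2ccc(F)cc2)n1-c1ccccc1` reaches only the limit > 500 ug/mL in this assay. Compound 4 `O=C(CSc1ncccn1)N/N=c1/scc(-c2ccccc2)n1-c1ccccc1` differs from compound 2 by pyrimidin-2-yl in place of 1-phenyl-1H-tetrazol-5-yl on a sulfur. Among the compounds with values here, no measured pair carries this exchange, so the single measured step does not bear on it; the only hint is that compound 1, which also holds pyrimidin-2-yl, sits at the limit of > 500 ug/mL in this assay, at which 1 of the 3 values shown sits. Compound 4 is therefore estimated at 480 ug/mL, ranging from 250 ug/mL to 900 ug/mL. The step of a 1.2-fold higher number from compound 2 to compound 4 (0.06 log units; within the scatter) is expected to be small.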

Compound 4, half-maximal inhibitory concentration: 107 ug/mL
The estimate for compound 4 lay 4.5-fold (0.65 log units) above the measured number; measured number outside the range, below it.
By their numbers in this assay, from the lowest: compound 4; then compounds 3 and 2 (each within the scatter of the next). At a limit, above all of these: compound 1.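

In this assay, pyrimidin-2-yl in place of 1-phenyl-1H-tetrazol-5-yl on a sulfur now has a measured pair, and the exchange reaches beyond the scatter: a 3.9-fold lower number from compound 2 to compound 4 (0.59 log units; beyond the scatter). With pyrimidin-2-yl held, hydrogen in place of fluoro on an aromatic carbon also counts, as an at least 4.6-fold lower number from compound 1 to compound 4 (0.66 log units; beyond the scatter). That step rests on a limit of the assay held by compound 1: the limit of > 500 ug/mL in this assay, at which 1 of the 4 values shown sits.

Open remains how an amine or a carboxylic acid on this sulfur would read. Also open, from the compounds shown here alone, is whether the exchange to pyrimidin-2-yl would give a similar step with chloro on the aromatic carbon.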